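The source may report more compounds than this note shows. Statements on the series, on what has been measured and on what is new or still open speak of the compounds shown alone.

In a functional assay on MCF7 cells (Homo sapiens) for antiproliferative activity, read by CellTiter-Glo, with a stated time of 5 days (on this read-out higher numbers stand for weaker inhibition and lower numbers for stronger inhibition), compound 1 (`CC/C(=C(/c1ccc(/C=C/C(=O)O)cc1)c1ccc(-c2cncs2)cc1)c1ccccc1`) gives 31 nM and compound 2 (`O=C(O)/C=C/c1ccc(/C(=C(\c2ccccc2)C2CCC2)c2ccc3scnc3c2)cc1`) gives 16 nM. For the measured compounds named here, these two values lie within the usual scatter of each other, so compound 2 stands level with compound 1 on the numbers so far. Compound 3 (`O=C(O)/C=C/c1ccc(/C(=C(\c2ccccc2)C2CCC2)c2ccc(-c3cncs3)cc2)cc1`) departs from compound 2 in one place: 4-(1,3-thiazol-5-yl)phenyl in place of 1,3-benzothiazol-5-yl on a double-bonded chain carbon bound to an aromatic carbon and a double-bonded chain carbon. Here 4-(1,3-thiazol-5-yl)phenyl replaces 1,3-benzothiazol-5-yl on a double-bonded chain carbon bound to an aromatic carbon and a double-bonded chain carbon. Going by the values given here, no measured pair shows this swap alone. However, compound 1 already carries the entering group and gives 31 nM, so a large loss seems unlikely. The expected change is small, with no shift in either direction beyond the scatter: the estimated step is a 1.3-fold higher number from compound 2 to compound 3 (0.10 log units; within the scatter). For compound 3 the estimated value is 20 nM, within an expected range of 6 nM to 65 nM.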

Compound 3, half-maximal inhibitory concentration: 9.2 nM
Compound 3: the middle estimate sits 2.2-fold (0.34 log units) above what was measured, within the range that was stated.
By their numbers in this assay, from the lowest: compounds 3, 2 and 1 (each within the scatter of the next, the first and the last beyond it).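

In this assay, 4-(1,3-thiazol-5-yl)phenyl in place of 1,3-benzothiazol-5-yl gives a 1.7-fold lower number from compound 2 to compound 3 (0.24 log units; within the scatter), so on this double-bonded chain carbon the two aromatic groups cannot be told apart. Cyclobutyl in place of ethyl, with 4-(1,3-thiazol-5-yl)phenyl kept in both compounds, gives a 3.4-fold lower number from compound 1 to compound 3 (0.53 log units; beyond the scatter), the only step here beyond the scatter, so this modest gain in inhibition belongs to the change from ethyl to cyclobutyl. Nothing available explains either step.

The compounds shown leave open whether the cyclobutyl gain carries over to compounds bearing 1,3-benzothiazol-5-yl. They also leave open how a cyclopropyl group or a longer chain would behave in place of cyclobutyl.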